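This account rests on a few compounds, and the source may have more. Where it says the series, first, only, none or still open, it means among the compounds named here.

Measured in a functional assay on M14 cells (Homo sapiens) for antiproliferative activity, read by sulforhodamine B assay, with a stated time of 48 h; a lower number here means a stronger inhibitor, a higher number a weaker inhibitor:
- compound 1 `COc1cc(-c2nn(-c3ccc(NC(=O)Nc4ccc(Cl)c(Cl)c4)cc3)cc2-c2ccncc2)ccc1Cl`: 2560 nM
- compound 2 `COc1cc(-c2nn(-c3ccc(NC(=O)Nc4ccc(Cl)c(C(F)(F)F)c4)cc3)cc2-c2ccncc2)ccc1Cl`: 1740 nM
- compound 3 `COc1cc(-c2nn(-c3ccc(NC(=O)c4ccc(Cl)c(Cl)c4)cc3)cc2-c2ccncc2)ccc1Cl`: 22400 nM

Compound 3 carries the highest number of the three, as an 8.8-fold higher number from compound 1 to compound 3 (0.94 log units; beyond the scatter) and a 13-fold higher number from compound 2 to compound 3 (1.11 log units; beyond the scatter) show.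

Compound 4 `COc1cc(-c2nn(-c3ccc(NC(=O)c4ccc(Cl)c(C(F)(F)F)c4)cc3)cc2-c2ccncc2)ccc1Cl` is not yet measured. Its difference is trifluoromethyl in place of chloro on an aromatic carbon. For the measured compounds named here, the one measured step with this exchange is a 1.5-fold lower number from compound 1 to compound 2 (0.17 log units; within the scatter), which stays within the scatter. The other two steps change a different part of the structure and bear on it only weakly. Going by these compounds, the exchange remains untested on the amide of compound 3. In this assay the expected step is a 1.5-fold lower number from compound 3 to compound 4 (0.17 log units; within the scatter), so no shift beyond the scatter is expected.

Compound 4 is estimated at 15000 nM, with an expected range of 6000 nM to 35000 nM.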

Compound 4, half-maximal inhibitory concentration: 1920 nM
Estimate against measurement, compound 4: 7.8-fold (0.89 log units) above; measured number outside the range, below it.
By their numbers in this assay, from the lowest: compounds 2, 4 and 1 (each within the scatter of the next); then compound 3.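

On the amide, trifluoromethyl in place of chloro gives a 12-fold lower number from compound 3 to compound 4 (1.07 log units; beyond the scatter), so in this assay the exchange is not neutral at this position and its size differs between the two cores: the same change on two cores in this assay, a 1.5-fold lower number (0.17 log units; within the scatter) from compound 1 to compound 2 and a 12-fold lower number (1.07 log units; beyond the scatter) from compound 3 to compound 4, 7.9-fold (0.90 log units) apart, beyond the scatter of two such steps

The amide with 4-chloro-3-(trifluoromethyl)phenyl stands level with both ureas, with a 1.1-fold higher number from compound 2 to compound 4 (0.04 log units; within the scatter) and a 1.3-fold lower number from compound 1 to compound 4 (0.12 log units; within the scatter). The loss on going from urea to amide therefore appears with 3,4-dichlorophenyl but not with 4-chloro-3-(trifluoromethyl)phenyl.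

Open, going by these compounds, is whether a nitrile or a methyl group at this position would follow trifluoromethyl or chloro on the amide, and whether the urea would again show a smaller step.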